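Working notes: from compound 3 to compound 4

A few compounds are considered here, and "the series" means these few. Any claim that something is new, unique, unknown or untested is made for them only; others in the source may bear on it.

In a functional assay on BGC-823 cells (Homo sapiens) for antiproliferative activity, read by MTT assay, with a stated time of 24 h (on this read-out higher numbers stand for weaker inhibition and lower numbers for stronger inhibition), compound 1 (`O=[N+]([O-])c1cccc(CSc2nnc(-c3ccc4c(c3)OCCO4)n2-c2ccccc2)c1`) gives 30100 nM and compound 2 (`O=[N+]([O-])c1ccc(CSc2nnc(-c3ccc4c(c3)OCCO4)n2-c2ccccc2)cc1`) gives 48600 nM while compound 3 (`Cc1ccc(CSc2nnc(-c3ccc4c(c3)OCCO4)n2-c2ccccc2)cc1`) stands at 44300 nM within the scatter of both. The change to compound 4 (`Brc1ccccc1CSc1nnc(-c2ccc3c(c2)OCCO3)n1-c1ccccc1`) is 2-bromophenyl in place of 4-methylphenyl on a saturated chain carbon bound to a sulfur. Going by the values given here, no measured compound carries a 2-bromophenyl group, so a direct comparison is lacking. The nearest evidence comes from three steps in the same group: a 1.6-fold higher number from compound 1 to compound 2 (0.21 log units; within the scatter) and a 1.5-fold higher number from compound 1 to compound 3 (0.17 log units; within the scatter) and a 1.1-fold lower number from compound 2 to compound 3 (0.04 log units; within the scatter) all stay within the scatter. On these three small steps, compound 4 is expected in this assay to show no step beyond the scatter, in either direction. The estimate amounts to a 1.1-fold lower number from compound 3 to compound 4 (0.04 log units; within the scatter) as the expected step. For compound 4 the estimated value is 40000 nM with an expected range of 20000 nM to 80000 nM on present data.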

Compound 4, half-maximal inhibitory concentration: > 100000 nM
Compound 4 was reported as a limit (the forecaster's own chance of this, stated with the estimate: 5%); at least 2.5-fold (0.39 log units) between middle value and limit.
By their numbers in this assay, from the lowest: compounds 1, 3 and 2 (each within the scatter of the next). At a limit, above all of these: compound 4.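

In this assay compound 4 is reported only as a limit, not as a number: the limit of > 100000 nM in this assay, at which 1 of the 4 values shown sits. The aryl group on a saturated chain carbon bound to a sulfur is not indifferent to change, as the 3-nitrophenyl, 4-nitrophenyl and 4-methylphenyl groups alone suggested: the steps to 2-bromophenyl are an at least 2.2-fold higher number from compound 3 to compound 4 (0.35 log units; beyond the scatter), an at least 2.0-fold higher number from compound 2 to compound 4 (0.31 log units; beyond the scatter) and an at least 3.3-fold higher number from compound 1 to compound 4 (0.52 log units; beyond the scatter). All three are minimum sizes and the first in the series beyond the scatter, and the 2-bromophenyl group differs from the others both in its substituent and in where that substituent sits.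

A 4-bromophenyl or 2-methylphenyl group would be needed to separate bromine from its place on the ring. Going by these compounds, how a 4-aminophenyl or 4-carboxyphenyl group would read here also stays open, as does the true size of the step to compound 4.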